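The source may report more compounds than this note shows. Statements on the series, on what has been measured and on what is new or still open speak of the compounds shown alone.

Working notes on the series.

Compound 1 `COc1ccc(Br)cc1-c1ccn(-c2ccccc2)n1` and compound 2 `COc1ccc(Br)cc1-c1ccn(Cc2ccccc2)n1` share a core; compound 3 `C=CCc1ccc(O)c(-c2ccn(-c3ccccc3)n2)c1` and compound 4 `C=CCc1ccc(O)c(-c2ccn(Cc3ccccc3)n2)c1` share another, and the difference between the two cores is not broken down here. In a functional assay on BV-2 cells (Mus musculus) for inhibition, read by Griess assay, with a stated time of 24 h (on this read-out higher numbers stand for weaker inhibition and lower numbers for stronger inhibition), compound 1 gives > 200000 nM, a limit of the assay. In this assay compound 2 gives > 200000 nM, also a limit. The change between them, (benzyl in place of phenyl on an aromatic nitrogen), therefore gives a step that the two limits leave unreadable from compound 1 to compound 2, because of the limit of > 200000 nM in this assay, at which 2 of the 3 values shown sit. In this assay, for the measured compounds named here, compound 3 gives 73000 nM, the only number in the set.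

Compound 4 carries the same kind of change, (benzyl in place of phenyl on an aromatic nitrogen); the place differs only in that the ring atom two bonds away bears a large group rather than a group of 9 heavy atoms. The measured pair gives no readable size, so the step of a 1.0-fold lower number from compound 3 to compound 4 (0.02 log units; within the scatter) is expected to be small. Compound 4 is estimated at 70000 nM, between 20000 nM and 200000 nM.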

Compound 4, half-maximal inhibitory concentration: 92500 nM
Estimate against measurement, compound 4: 1.3-fold (0.12 log units) below; the range from low to high includes it.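

In this assay, benzyl in place of phenyl on the aromatic nitrogen gives a 1.3-fold higher number from compound 3 to compound 4 (0.10 log units; within the scatter), so on the core of compound 3 the two groups are not told apart. On the core of compound 1 the same replacement yields a step that cannot be read, because both values there are limits: the limit of > 200000 nM in this assay, at which 2 of the 4 values shown sit. The series therefore shows no difference beyond the scatter on one core only, and it does not show whether that result carries over to the other core.

Still open, as far as these compounds go, is how a group such as a phenethyl chain, or a benzyl bearing an amine or a carboxylic acid, would read on this aromatic nitrogen. From the compounds shown here alone, whether any such group would give a readable step on either core also remains open.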